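Shrinking the amine on a kinase-inhibitor core

The source may hold more compounds than are shown below. What is called first, only, known or untested is meant among the compounds shown, and "the series" means these compounds.

Measured compounds:
compound 1, `Cn1c(N2CCCC2)c(C#N)c2c(N)ncnc21`, 1480 nM
compound 2, `CN(C)c1c(C#N)c2c(N)ncnc2n1C`, 4620 nM
compound 3, `C[C@H]1CCCN1c1c(C#N)c2c(N)ncnc2n1C`, 5660 nM

All three were tested in an assay on isolated protein for inhibition of Leucine-rich repeat serine/threonine-protein kinase 2 (Homo sapiens), read by TR-FRET and LanthaScreen, with stated times of 50 min and 30 min, in the presence of a further agent that is not named here; a higher number here means a weaker inhibitor, a lower number a stronger inhibitor. Compound 3 gives the highest number of the three, so it is the weakest inhibitor shown; against compound 2 the gap is a 1.2-fold higher number from compound 2 to compound 3 (0.09 log units; within the scatter), which does not separate the two, while against compound 1 the gap is a 3.8-fold higher number from compound 1 to compound 3 (0.58 log units; beyond the scatter).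

Compound 4, `Cn1c(N)c(C#N)c2c(N)ncnc21`, has not yet been measured. It differs from compound 3 by amino in place of 2-methylpyrrolidin-1-yl on an aromatic carbon: the whole five-membered saturated ring is cut away and a bare amino group takes its place.

Among the measured compounds shown here, two measured steps bear on this. Replacing the pyrrolidine of compound 1 with a dimethylamino gave a 3.1-fold higher number from compound 1 to compound 2 (0.49 log units; beyond the scatter), and adding a methyl to that ring gave a 3.8-fold higher number from compound 1 to compound 3 (0.58 log units; beyond the scatter). Both show that changing this amine moves the number, but they do not point in a single direction for a group smaller than any tried so far. Compound 4 is therefore expected to land near compound 3, with the step of a 1.1-fold higher number from compound 3 to compound 4 (0.03 log units; within the scatter) most likely within the scatter, though a larger move either way cannot be ruled out. The estimate for compound 4 is 6000 nM, with a range from 1500 nM to 20000 nM.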

Compound 4, half-maximal inhibitory concentration: 14400 nM
Estimate against measurement, compound 4: 2.4-fold (0.38 log units) below, within the range that was stated.
By their numbers in this assay, from the lowest: compound 1; then compounds 2 and 3 (each within the scatter of the next); then compound 4.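

In this assay, trimming the amine on this aromatic carbon down to a bare amino group costs inhibition against every earlier compound: a 2.5-fold higher number from compound 3 to compound 4 (0.41 log units; beyond the scatter), a 3.1-fold higher number from compound 2 to compound 4 (0.49 log units; beyond the scatter) and a 9.7-fold higher number from compound 1 to compound 4 (0.99 log units; beyond the scatter). This is the first sign that the smallest group tried here is the poorest of the four, making compound 4 the weakest inhibitor shown, although the trend is not a simple one of bigger being better, since compound 3 goes against it by carrying an extra methyl on the ring of compound 1 and still giving a higher number. No evidence is available to explain these shifts.

The compounds shown leave open how the number changes between the amino group and dimethylamino, which a methylamino group at this carbon could help to settle. They also leave open whether a larger saturated ring, such as piperidine or morpholine, would give a lower number than the pyrrolidine of compound 1, and whether the other stereoisomer of the 2-methylpyrrolidin-1-yl group would differ from compound 3.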